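Benzyl for Cyclohexyl on a Furanyl Triazolotriazine Core

The compounds below may be only part of what the source reports. "The series", "measured", "known", "first", "only" and "open" are said of these compounds alone.

Compound 1 `CC(C)Nc1nc(N)n2nc(-c3ccco3)nc2n1`: 4310 nM
Compound 2 `c1coc(-c2nc3nc(NC4CCCCC4)nc(NC4CCCCC4)n3n2)c1`: 306 nM

In an assay on CHO cells for displacement of a labelled ligand from adenosine receptor A1 (Homo sapiens) (on this read-out higher numbers stand for weaker inhibition and lower numbers for stronger inhibition), compound 1 gives 4310 nM, while compound 2 gives 306 nM and so holds the lower of the two numbers, with compound 1 standing well beyond the scatter above it. Compound 3 `c1ccc(CNc2nc(NC3CCCCC3)n3nc(-c4ccco4)nc3n2)cc1` is not yet measured. It differs from compound 2 by benzyl in place of cyclohexyl on a nitrogen on an aromatic ring. Among the compounds with values here, since no measured pair shows this exchange, the expected step from compound 2 to compound 3 in this assay is a 1.6-fold higher number from compound 2 to compound 3 (0.21 log units; within the scatter), a modest move toward weaker inhibition that may not exceed the scatter. Compound 3 is therefore estimated at 500 nM, within 120 nM to 2000 nM.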

Compound 3, inhibition constant: 63.9 nM
Compound 3: the middle estimate sits 7.8-fold (0.89 log units) above what was measured; the measured number lies below the stated range.
By their numbers in this assay, from the lowest: compound 3; then compound 2; then compound 1.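

In this assay, within the data shown here, benzyl in place of cyclohexyl on a nitrogen on an aromatic ring gives a 4.8-fold lower number from compound 2 to compound 3 (0.68 log units; beyond the scatter) and is the only step here between compounds that differ in one place. It shows that changing this one substituent can move the number beyond the scatter, which compound 1 and compound 2, differing in more than one place, could not show. Nothing at hand explains the size or direction of this step. Open, from the compounds shown here alone, is how a phenethyl group or a pyridylmethyl group would read on this nitrogen. Also open, going by these compounds, is whether benzyl in place of the remaining cyclohexyl of compound 3 would give a similar step.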